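A few compounds are considered here, and "the series" means these few. Any claim that something is new, unique, unknown or untested is made for them only; others in the source may bear on it.

Working notes on the series. Two compounds have numbers in a functional assay on HeLa cells (Homo sapiens) for cytotoxicity, read by MTT assay; on this read-out lower numbers stand for stronger inhibition and higher numbers for weaker inhibition. Compound 1 `CC(C)=CC[C@@H](OC[C@@H](C)O)C1=CC(=O)c2c(O)ccc(O)c2C1=O` gives 22500 nM. Compound 2 `CC(C)=CC[C@@H](OC(=O)CC(O)c1ccccc1)C1=CC(=O)c2c(O)ccc(O)c2C1=O` gives 44500 nM. For the measured compounds named here, the two values lie within the scatter of each other, so compound 1 cannot be set apart from compound 2 on these numbers, and no ordering of the pair is claimed. Compound 3 `CCC(CO[C@H](CC=C(C)C)C1=CC(=O)c2c(O)ccc(O)c2C1=O)OC(C)=O` has no value yet. It differs from compound 1 in one place: 1-acetoxypropyl in place of 1-hydroxyethyl on a saturated chain carbon bound to an oxygen on a saturated carbon. Going by the values given here, no step between measured compounds covers this change; of compound 2 one can say only that its value sits within the scatter of that of compound 1. The expected step from compound 1 to compound 3 is a 1.3-fold higher number from compound 1 to compound 3 (0.12 log units; within the scatter), that is, no change beyond the scatter in either direction. The value expected for compound 3 is 30000 nM, with a range from 12000 nM to 75000 nM.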

Compound 3, half-maximal inhibitory concentration: 44000 nM
Compound 3: middle estimate off by 1.5-fold (0.17 log units), on the low side, within the range that was stated.
By their numbers in this assay, from the lowest: compounds 1, 3 and 2 (each within the scatter of the next).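

In this assay, 1-acetoxypropyl in place of 1-hydroxyethyl on a saturated chain carbon bound to an oxygen on a saturated carbon gives a 2.0-fold higher number from compound 1 to compound 3 (0.29 log units; within the scatter). For the compounds shown here, this is the first step that can be read at this position, and it shows that going from 3 heavy atoms and 1 hydrogen-bond donor in 1-hydroxyethyl to 7 heavy atoms and 0 hydrogen-bond donors in 1-acetoxypropyl leaves the number within the scatter. No measurement bears on the reason for this result.

Open, from the compounds shown here alone, is whether an amine, a carboxylic acid or a longer chain in this place would give a number beyond the scatter of compound 1. The compounds shown also do not separate the added chain carbon from the acetyl group, as 1-hydroxypropyl would.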